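This account rests on a few compounds, and the source may have more. Where it says the series, first, only, none or still open, it means among the compounds named here.

Measured compounds and their values in an assay on VSM-A10 cells for antagonist activity at Endothelin-1 receptor (Rattus norvegicus); a lower number here means a stronger inhibitor, a higher number a weaker inhibitor:

Compound 1, `Cc1noc(NS(=O)(=O)c2cccc3c(N(C)C)cccc23)c1Cc1ccccc1`: 50000 nM
Compound 2, `Cc1noc(NS(=O)(=O)c2ccc(NC(=O)Nc3ccccc3)cc2)c1C`: 38000 nM
Compound 3, `Cc1noc(NS(=O)(=O)c2cccc3c(Cl)cccc23)c1C`: 24000 nM

In this assay compound 1 gives 50000 nM, the highest of the three numbers. Compound 2 gives 38000 nM, which sits within the usual scatter of the number for compound 1, so the two cannot be told apart. Compound 3 gives 24000 nM, a lower number that lies beyond the scatter relative to compound 1, and so marks somewhat stronger inhibition.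

The compound not yet measured is compound 4, `CCOC(=O)c1c(C)noc1NS(=O)(=O)c1cccc2c(N(C)C)cccc12`. It differs from compound 1 in one place: ethoxycarbonyl in place of benzyl on an aromatic carbon. For the measured compounds named here, no pair of measured compounds isolates this change, and compound 3 differs from compound 1 in more than one place, so its number cannot be tied to the group on the five-membered ring alone. Going by the values given here, the three compounds measured so far all sit in a narrow and weak band. On that basis the step from compound 1 to compound 4 in this assay is expected to be small, if anything toward a lower number, and not clearly beyond the scatter: a 1.7-fold lower number from compound 1 to compound 4 (0.22 log units; within the scatter). Compound 4 is therefore estimated at 30000 nM, with a range from 8000 nM to 100000 nM.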

Compound 4, half-maximal inhibitory concentration: 31000 nM
Compound 4: the middle estimate sits 1.0-fold (0.01 log units) below what was measured; measured number inside the range.
By their numbers in this assay, from the lowest: compounds 3, 4, 2 and 1 (each within the scatter of the next, the first and the last beyond it).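

In this assay, putting ethoxycarbonyl in place of benzyl on this aromatic carbon of the five-membered ring gives a 1.6-fold lower number from compound 1 to compound 4 (0.21 log units; within the scatter), the first step among these compounds that isolates a single change at this position. The step shows that the two compounds cannot be told apart, even though the entering group has no ring, has fewer heavy atoms and brings two hydrogen-bond acceptors where benzyl has none, so neither the six-membered aromatic ring of benzyl nor its carbon-only make-up is tied here to any difference that can be read. No measurement bears on why the two groups give numbers this close.

From the compounds shown here alone, what a carboxylic acid, an amine or a longer chain on this carbon would do to the number remains open, and so does whether any group here could bring inhibition beyond the scatter of compound 1. Compound 3 carries a methyl group at this place, but it also differs from compound 1 elsewhere, so the effect of methyl alone on the core of compound 1 cannot be read from it.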